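This account rests on a few compounds, and the source may have more. Where it says the series, first, only, none or still open, it means among the compounds named here.

Compound 1 `C=CC1=C(C(=O)NCc2ccccc2F)C(c2ccc(F)cc2)OC1` sits at the top of the range in a functional assay on HeLa cells (Homo sapiens) for cytotoxicity, read by MTT assay, with a stated time of 24 h; on this read-out higher numbers stand for weaker inhibition and lower numbers for stronger inhibition: compound 1 gives > 100000 nM, which is a limit of the assay rather than a number. Compound 2 `C=CC1=C(C(=O)Nc2ccc(OCC)cc2)C(c2ccc(OC)cc2)OC1` likewise returns only a limit, with compound 2 giving > 100000 nM in this assay. Compound 1 therefore stands at the limit of > 100000 nM in this assay, at which 2 of the 2 values shown sit. Compound 3 `C=CC1=C(C(=O)Nc2cccc(C)c2)C(c2ccc(F)cc2)OC1` carries 3-methylphenyl in place of 2-fluorobenzyl on an amide-type nitrogen, that is, 3-methylphenyl in place of 2-fluorobenzyl on an amide-type nitrogen. No shift beyond the scatter is expected, so the step is estimated as a step that the limit leaves unreadable from compound 1 to compound 3. Compound 3 is expected to give 150000 nM, between 60000 nM and 400000 nM, most likely reported again only as a limit.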

Compound 3, half-maximal inhibitory concentration: "not active" (no number reported)
Nothing numeric was reported for compound 3; no gap can be computed for the estimate.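

No step can be read between compound 1 and compound 3: compound 1 gives only a limit, and compound 3 is reported as "not active" without a number. The compounds shown leave open whether any group on the amide-type nitrogen yields a measurable value.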